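The compounds below may be only part of what the source reports. "The series", "measured", "known", "first", "only" and "open" are said of these compounds alone.

Measured so far in an assay for binding affinity to melatonin receptor (Gallus gallus); a lower number here means a stronger inhibitor, a higher number a weaker inhibitor:
compound 1 `COc1ccccc1CCCNC(C)=O` gives 1430 nM
compound 2 `CCC(=O)NCCCc1ccccc1OC` gives 374 nM
compound 3 `CCC(=O)NCCCCc1cccc(OC)c1` gives 119 nM

Compound 3 carries the lowest number of the three. How the core of compound 3 differs from the core of compound 1 is not broken down here. Between compound 1 and compound 2 the change is methyl in place of hydrogen on a saturated chain carbon bound to a carbonyl carbon and it gave a 3.8-fold lower number from compound 1 to compound 2 (0.58 log units; beyond the scatter). Compound 4 `CCCC(=O)NCCCCc1cccc(OC)c1` is not yet measured; relative to compound 3 it carries methyl in place of hydrogen on a saturated chain carbon, two bonds along the chain from a carbonyl carbon. This is the same kind of change, but the place differs: in compound 2 the methyl enters on a saturated chain carbon bound to a carbonyl carbon, whereas in compound 4 it enters two bonds along the chain from a carbonyl carbon. Resting on the step from compound 1 to compound 2, a somewhat smaller improvement is expected, a 2.0-fold lower number from compound 3 to compound 4 (0.30 log units; within the scatter). Compound 4 is thus estimated at 60 nM, within 20 nM to 200 nM.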

Compound 4, inhibition constant: 208 nM
Beside the measured number, compound 4's estimate is 3.5-fold (0.54 log units) below it; the measured number lies above the stated range.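

On the core of compound 3, methyl in place of hydrogen two bonds along the chain from a carbonyl carbon gives a 1.7-fold higher number from compound 3 to compound 4 (0.24 log units; within the scatter), so compound 3 and compound 4 cannot be told apart in this assay. The improvement seen on the earlier step therefore does not carry over to this core and place, and the two steps differ: the same change on two cores in this assay, a 3.8-fold lower number (0.58 log units; beyond the scatter) from compound 1 to compound 2 and a 1.7-fold higher number (0.24 log units; within the scatter) from compound 3 to compound 4, 6.7-fold (0.82 log units) apart, beyond the scatter of two such steps Which of core and place accounts for this gap remains unresolved, as the two steps differ in both.

Open, going by these compounds, is what the same methyl does two bonds along the chain from a carbonyl carbon on the core of compound 1. Also open, on these data alone, is how a longer chain or a terminal amine on the acyl side would read on the core of compound 3.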